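Adding a methoxy group to the phenoxy ring of compound 1

This account rests on a few compounds, and the source may have more. Where it says the series, first, only, none or still open, it means among the compounds named here.

Measured so far in an ADME assay on HepG2 cells (Homo sapiens) for cytotoxicity, read by luminescence, CellTiter-Glo and ATP content, with a stated time of 72 h; a lower number here means that less compound is needed, a higher number that more compound is needed for the effect:
- compound 1 `COc1cccc(CNCCCNc2ccnc3cc(Oc4ccccc4)ccc23)c1O` gives 6800 nM
- compound 2 `c1ccc(Oc2ccc3c(NCCCNCc4ccco4)ccnc3c2)cc1` gives 15200 nM
- compound 3 `COc1ccc(F)cc1CNCCCNc1ccnc2cc(Oc3ccccc3)ccc12` gives 1500 nM

Compound 1 stands second highest of the three numbers. Its nearest neighbour is compound 2, reached by a 2.2-fold higher number from compound 1 to compound 2 (0.35 log units; beyond the scatter), and its furthest is compound 3, reached by a 4.5-fold lower number from compound 1 to compound 3 (0.66 log units; beyond the scatter). The remaining pair, a 10-fold lower number from compound 2 to compound 3 (1.01 log units; beyond the scatter), is the largest step among the measured compounds. All three steps change only the aryl group on the saturated chain carbon bound to the amine nitrogen.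

Compound 4 `COc1ccccc1Oc1ccc2c(NCCCNCc3cccc(OC)c3O)ccnc2c1` differs from compound 1 elsewhere: methoxy in place of hydrogen on an aromatic carbon. Read one bond further out, the phenoxy becomes 2-methoxyphenoxy. Going by the values given here, none of the measured steps touches this part of the shared core, so no step bears directly on the change. With the known steps ranging from modest to large, but all at a different place, the expectation for a 1.1-fold lower number from compound 1 to compound 4 (0.05 log units; within the scatter) is a step that stays within the usual scatter. Compound 4 is therefore estimated at 6000 nM, with a range from 2500 nM to 15000 nM.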

Compound 4, half-maximal effective concentration: 11200 nM
Compound 4: middle estimate off by 1.9-fold (0.27 log units), on the low side; the measured number falls inside the stated range.
By their numbers in this assay, from the lowest: compound 3; then compounds 1, 4 and 2 (each within the scatter of the next, the first and the last beyond it).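

Adding methoxy to the phenoxy ring, which turns it into the 2-methoxyphenoxy of compound 4, gives a 1.6-fold higher number from compound 1 to compound 4 (0.22 log units; within the scatter) in this assay, so compounds 1 and 4 cannot be told apart in this assay. Going by these compounds alone, this is the first view of the phenoxy end of the molecule, as the earlier steps changed only the aryl group on the chain, and there a 4.5-fold lower number from compound 1 to compound 3 (0.66 log units; beyond the scatter) did exceed the scatter. On the background of compound 1, a methoxy on an aromatic carbon ortho to a large group therefore leaves the cytotoxicity reading indistinguishable, and no measurement shown here offers an explanation for this result.

The compounds shown leave open whether a different group at this place, such as a fluorine, an amine or a carboxylic acid, would give a step beyond the scatter. They also leave open whether the 2-methoxyphenoxy would behave in the same way when paired with the 5-fluoro-2-methoxyphenyl group of compound 3, which has the lowest number of the set at 1500 nM in this assay.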